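Amide nitrogen substituent: aromatic ring to cyclohexyl

This account rests on a few compounds, and the source may have more. Where it says the series, first, only, none or still open, it means among the compounds named here.

Measured so far in this series:
- Compound 1 `COc1cc(-c2cc(C(=O)O)c3ccccc3n2)ccc1OCC(=O)Nc1cccc(C)c1`; in an ADME assay on HaCaT cells (Homo sapiens) for inhibition (a lower number here means a stronger inhibitor, a higher number a weaker inhibitor), compound 1 gives 225000 nM.
- Compound 2 `COc1cc(-c2cc(C(=O)O)c3ccccc3n2)ccc1OCC(=O)Nc1ccc(Cl)cc1`; in this assay compound 2 gives only the limit > 300000 nM.

Compound 2 thus stands at the limit of > 300000 nM in this assay, at which 1 of the 2 values shown sits, and no number is known for it, only that limit. For the measured compounds named here, the single measured step, an at least 1.3-fold higher number from compound 1 to compound 2 (0.12 log units; that floor lies within the scatter), is an exchange of one aromatic group for another on the amide-type nitrogen, and its floor lies within the scatter.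

Compound 3 `COc1cc(-c2cc(C(=O)O)c3ccccc3n2)ccc1OCC(=O)NC1CCCCC1` carries the next change: cyclohexyl in place of 4-chlorophenyl on an amide-type nitrogen. Going by the values given here, because the only measured step is an at least 1.3-fold higher number from compound 1 to compound 2 (0.12 log units; that floor lies within the scatter), a swap between two aromatic groups, nothing measured speaks directly to an aromatic ring giving way to a non-aromatic ring at this position. In this assay compound 3 is therefore expected to sit near the limit again, with no step beyond the scatter foreseen. Compound 3 is estimated at 300000 nM, within 150000 nM to 600000 nM. The expected step is a number no higher from compound 2 to compound 3 (the limit leaves the size open).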

Compound 3, half-maximal inhibitory concentration: > 300000 nM
Compound 3 ended at the assay's limit; the forecaster's own chance of this, stated with the estimate: 60%; the middle value lies on the limit itself.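

In this assay compound 3 gives > 300000 nM, which is a limit of the assay and not a number. A non-aromatic ring on the amide-type nitrogen therefore gives no readable value here either, and the step between compound 2 and compound 3 cannot be read. The only readable result for cyclohexyl is an at least 1.3-fold higher number from compound 1 to compound 3 (0.12 log units; that floor lies within the scatter), so neither aromatic nor non-aromatic rings show a change beyond the scatter at this position, and the series gathers at one end of the range: the limit of > 300000 nM in this assay, at which 2 of the 3 values shown sit.

On these data alone, it remains open whether any group on this nitrogen gives a value clearly below the limit. A benzyl group, a longer alkyl chain or a cyclohexyl ring carrying an amine would test this.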